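The source may hold more compounds than are shown below. What is called first, only, known or untested is meant among the compounds shown, and "the series" means these compounds.

Measured compounds:
- compound 1, `COc1ccc(S(=O)(=O)Nc2nc(-c3cccc([N+](=O)[O-])c3)cs2)cc1`: 51 nM
- compound 2, `O=C(O)c1cc(-c2cccc([N+](=O)[O-])c2)on1`: 2680 nM

In an assay on isolated protein for inhibition of kynurenine 3-monooxygenase (Rattus norvegicus) (on this read-out lower numbers stand for stronger inhibition and higher numbers for weaker inhibition), compound 1 gives 51 nM, while compound 2 gives 2680 nM. Of these two numbers, compound 1 holds the lower one, and its gap to compound 2 lies well beyond the usual scatter of repeated measurements, so compound 1 is the stronger inhibitor of the pair. Compound 3, `O=[N+]([O-])c1cccc(-c2csc(NS(=O)(=O)c3ccc(Cl)cc3)n2)c1`, has not yet been measured in this assay. It differs from compound 1 in a single place: chloro in place of methoxy on an aromatic carbon. Among the compounds with values here, no step between measured compounds covers an exchange of this kind, so the numbers at hand show neither its size nor its direction. Compound 3 keeps the rest of compound 1 unchanged, and swapping methoxy for chloro para to a large group on a six-membered aromatic ring of carbon only is expected to be a small move. The expected step is a 1.3-fold lower number from compound 1 to compound 3 (0.11 log units; within the scatter), which stays within the scatter in either direction. Compound 3 is therefore estimated at 40 nM, with a range from 15 nM to 130 nM.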

Compound 3, half-maximal inhibitory concentration: 84 nM
Beside the measured number, compound 3's estimate is 2.1-fold (0.32 log units) below it; low and high end bracket the measured number.
By their numbers in this assay, from the lowest: compounds 1 and 3 (each within the scatter of the next); then compound 2.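

Within the data shown here, at the place para to a large group on the six-membered aromatic ring of carbon only, the exchange of 4-methoxyphenyl to 4-chlorophenyl gives the first reading of a single change in this assay, and it is a 1.6-fold higher number from compound 1 to compound 3 (0.22 log units; within the scatter), so compounds 1 and 3 cannot be put in order. The earlier compounds shown here could not show that this place accepts chloro for methoxy, including the loss of the methoxy oxygen, with the number staying within the scatter of compound 1. Nothing measured here gives a reason why the two groups read alike.

The compounds shown leave open how an amine, a carboxylic acid or a longer chain such as ethoxy would read at this same place, as methoxy and chloro are the only two groups seen there. Among these compounds, they also leave open whether this exchange would read alike on another core, and compound 2 differs from compound 1 in more than one place, so it offers no step that could settle this.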